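Amino in place of nitro: notes on compound 3

The compounds below may be only part of what the source reports. "The series", "measured", "known", "first", "only" and "open" are said of these compounds alone.

Among the compounds with values here, in a functional assay on SK-MEL cells (Homo sapiens) for cytotoxicity, read by MTT assay, with a stated time of 6 days (a higher number here means that more compound is needed for the effect, a lower number that less compound is needed), compound 2 `O=c1cc(-c2ccc([N+](=O)[O-])cc2)oc2ccc(O)cc12` gives 21 ug/mL, the only actual number so far. Compound 1 `COc1cc(-c2oc3ccccc3c(=O)c2C(=O)O)cc(OC)c1OC` stands at > 25 ug/mL, which is a limit of the assay. Compound 3 `Nc1ccc(-c2cc(=O)c3cc(O)ccc3o2)cc1` carries amino in place of nitro on an aromatic carbon, para to a large group (amino in place of nitro on an aromatic carbon). No measured step sizes this change, so the expected step stays within the usual scatter, leaning slightly toward less compound needed in this assay: a 1.6-fold lower number from compound 2 to compound 3 (0.21 log units; within the scatter). For compound 3 the estimated value is 13 ug/mL, with an expected range of 5 ug/mL to 25 ug/mL.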

Compound 3, concentration for half-maximal effect: 2.03 ug/mL
Compound 3: middle estimate off by 6.4-fold (0.81 log units), on the high side; the measured number lies below the stated range.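

In this assay the aromatic carbon para to a large group proves sensitive to its substituent: amino in place of nitro gives a 10-fold lower number from compound 2 to compound 3 (1.01 log units; beyond the scatter). Within the data shown here, this is the first sized single-place change, and it shows that this position alone can move the number well beyond the scatter. Nothing given here accounts for the size of this step.

The compounds shown place only nitro and amino at this carbon, so whether a dimethylamino group or an acetamide would keep the lower number remains open. Other positions on the shared core also remain unsized by any single-place step.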